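From acetyl to propylcarbonyl on compound 3

A few compounds are considered here, and "the series" means these few. Any claim that something is new, unique, unknown or untested is made for them only; others in the source may bear on it.

Measured so far in a functional assay on SK-MEL-28 cells (Homo sapiens) for antiproliferative activity; on this read-out higher numbers stand for weaker inhibition and lower numbers for stronger inhibition:
Compound 1 `Nc1nc(=O)n([C@H]2C=C[C@@H](CO)O2)cc1Br`: > 100000 nM (a limit)
Compound 2 `O=c1[nH]c(=O)n([C@@H]2C=C[C@H](CO)O2)cc1F`: 7450 nM
Compound 3 `CC(=O)OC[C@@H]1C=C[C@H](n2cc(F)c(N)nc2=O)O1`: > 100000 nM (a limit)

Compound 3 stands at > 100000 nM in this assay, which is a limit of the assay and not a number. Compound 1 also gives only a limit, > 100000 nM. Of the three compounds, only compound 2 gives a number, 7450 nM.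

The next compound is compound 4 `CCCC(=O)OC[C@@H]1C=C[C@H](n2cc(F)c(N)nc2=O)O1`. The change from compound 3 is ethyl in place of hydrogen on a saturated chain carbon bound to a carbonyl carbon, so acetoxy becomes (propylcarbonyl)oxy. The shared core stays as it is. Among the measured compounds shown here, no two measured compounds differ in one place only, so the series offers no direct precedent for the size of this step.

In this assay, no step beyond the scatter is expected, and a report of only a limit remains the likeliest outcome. The estimated change is an at least 1.2-fold lower number from compound 3 to compound 4 (0.09 log units; that floor lies within the scatter). For compound 4 the estimated value is 80000 nM, with an expected range of 25000 nM to 100000 nM.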

Compound 4, half-maximal inhibitory concentration: > 100000 nM
Compound 4 was reported as a limit; the forecaster's own chance of this, stated with the estimate: 65%; middle value at least 1.2-fold (0.09 log units) away from the limit.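

In this assay compound 4 gives > 100000 nM, a limit and not a number. Compound 3 also gives only a limit, so no step can be read between compound 3 and compound 4, because both sit at the same limit: the limit of > 100000 nM in this assay, at which 3 of the 4 values shown sit.

The compounds shown leave open what size of effect, if any, the change from acetoxy to (propylcarbonyl)oxy has on this read-out.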